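Adding benzyl to compound 3: a step from the limit

This account rests on a few compounds, and the source may have more. Where it says the series, first, only, none or still open, it means among the compounds named here.

In a functional assay on WiDr cells (Homo sapiens) for antiproliferative activity, read by sulforhodamine B assay, with a stated time of 48 h (on this read-out lower numbers stand for stronger inhibition of growth and higher numbers for weaker inhibition of growth), compound 1 (`CC(C)(C)[Si](C)(C)O[C@H]1CCCO[C@@H]1CO`) gives > 100000 nM as a limit of the assay, not a number. Compound 2 (`CC(C)(C)[Si](C)(C)O[C@@H]1CCCO[C@@H]1CO`) gives > 100000 nM as a limit too. Compound 3 (`CC(C)(C)[Si](C)(C)O[C@@H]1CCCO[C@@H]1COCC(=O)O`) gives > 100000 nM as a limit as well. Compound 3 therefore stands at the limit of > 100000 nM in this assay, at which 3 of the 3 values shown sit, and has no number of its own.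

Compound 4 (`CC(C)(C)[Si](C)(C)O[C@@H]1CCCO[C@@H]1COCC(=O)OCc1ccccc1`) differs from compound 3 by one change (benzyl in place of hydrogen on an oxygen next to a carbonyl group), benzyl in place of hydrogen on an oxygen next to a carbonyl group.

Within the data shown here, two measured steps bear on this change, and neither has a readable size. One is a step that the two limits leave unreadable from compound 1 to compound 2 and concerns only configuration, as shown by the fact that compounds 1 and 2 differ only in the configuration as drawn in this series. The other is a step that the two limits leave unreadable from compound 2 to compound 3 and gives no size to carry over either.

The expected move is an at least 1.6-fold lower number from compound 3 to compound 4 (0.22 log units; that floor lies within the scatter) and it is modest, toward stronger inhibition of growth, with a real chance that only the limit returns. In this assay the estimated value for compound 4 is 60000 nM with an expected range from 15000 nM to 100000 nM around it.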

Compound 4, concentration for 50% growth inhibition: 37000 nM
Compound 4: middle estimate off by 1.6-fold (0.21 log units), on the high side, within the range that was stated.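

In this assay, among these compounds, the earlier compounds gave no number to compare, only a limit of the assay: the limit of > 100000 nM in this assay, at which 3 of the 4 values shown sit. Benzyl in place of hydrogen on an oxygen next to a carbonyl group gives an at least 2.7-fold lower number from compound 3 to compound 4 (0.43 log units; beyond the scatter), the first step in this series with a readable size, which shows that growth inhibition responds to a change at this place. Among the compounds shown here, that size is a floor rather than an exact figure, and the earlier steps cannot be read.

The compounds shown do not tell whether a smaller group such as methyl, a longer chain such as phenethyl, or an amide in place of the ester would do the same. Nor do they tell whether benzyl would give a similar step with the configuration drawn in compound 1.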